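The source may hold more compounds than are shown below. What is called first, only, known or untested is meant among the compounds shown, and "the series" means these compounds.

Measured so far:
Compound 1 `O=C(CSCc1nc2cc([N+](=O)[O-])ccc2[nH]1)c1ccccc1` — in a functional assay on HCT-116 cells (Homo sapiens) for cytotoxicity, read by MTT assay, with a stated time of 48 h (a higher number here means a weaker inhibitor, a lower number a stronger inhibitor), compound 1 gives 12400 nM.
Compound 2 `O=C(CSCc1nc2cc([N+](=O)[O-])ccc2[nH]1)c1ccc(Br)cc1` — in this assay compound 2 gives 1780 nM.
Compound 3 `NNC(=O)CSCc1nc2cc([N+](=O)[O-])ccc2[nH]1` — in this assay compound 3 gives 5330 nM.

Compound 3 holds the second highest of the three numbers: the step of a 2.3-fold lower number from compound 1 to compound 3 (0.37 log units; beyond the scatter) separates it from compound 1, and the step of a 3.0-fold higher number from compound 2 to compound 3 (0.48 log units; beyond the scatter) separates it from compound 2. All three compounds share the same core and differ only in the group on the carbonyl carbon.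

Compound 4 `CC1=NN(C(=O)CSCc2nc3cc([N+](=O)[O-])ccc3[nH]2)C(=O)C1` changes that same place: a group of 7 heavy atoms (4 carbon, 2 nitrogen, 1 oxygen; one five-membered non-aromatic ring with 2 hetero atoms) in place of a group of 2 heavy atoms (2 nitrogen; no ring), on a carbonyl carbon. The two measured steps that touch this carbonyl carbon are a 2.3-fold lower number from compound 1 to compound 3 (0.37 log units; beyond the scatter) and a 3.0-fold higher number from compound 2 to compound 3 (0.48 log units; beyond the scatter); both were modest, and they point in opposite directions, so the group at this position has shifted the number only moderately so far. A comparable modest step is therefore expected for compound 4, with no firm direction, and the estimate leans slightly toward a lower number, a 1.3-fold lower number from compound 3 to compound 4 (0.12 log units; within the scatter). Compound 4 is expected to give about 4000 nM, somewhere between 1300 nM and 12000 nM.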

Compound 4, half-maximal inhibitory concentration: 5410 nM
The estimate for compound 4 lay 1.4-fold (0.13 log units) below the measured number; the range from low to high includes it.
By their numbers in this assay, from the lowest: compound 2; then compounds 3 and 4 (each within the scatter of the next); then compound 1.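

In this assay, replacing the aminoamino group on the carbonyl carbon with a five-membered non-aromatic ring with 2 hetero atoms gives a 1.0-fold higher number from compound 3 to compound 4 (0.01 log units; within the scatter), so two groups with quite different heavy-atom counts, rings and hydrogen-bond donor counts give numbers that cannot be told apart. The ring group also keeps the same place relative to the two aromatic groups, with a 2.3-fold lower number from compound 1 to compound 4 (0.36 log units; beyond the scatter) and a 3.0-fold higher number from compound 2 to compound 4 (0.48 log units; beyond the scatter), so compound 4 sits with compound 3 between the phenyl and 4-bromophenyl compounds. No measurement available here offers an explanation for this result.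

The compounds shown leave open whether a simple amine or a carboxylic acid on this carbonyl carbon would also match compound 3 and compound 4. They also leave open whether a chloro or methoxy group on the phenyl ring would give a step like that of bromo.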